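A few compounds are considered here, and "the series" means these few. Any claim that something is new, unique, unknown or untested is made for them only; others in the source may bear on it.

In a functional assay on MDA-MB-231 cells (Homo sapiens) for inhibition, read by MTT assay, with a stated time of 48 h (a lower number here means a stronger inhibitor, a higher number a weaker inhibitor), the three measured compounds share one core and differ in a single group. Compound 1 `COc1cc(-c2nccn3cc(-c4ccc(Cl)cc4)nc23)cc(OC)c1OC`, which carries chloro, gives 2090 nM. Compound 2 `COc1cc(-c2nccn3cc(-c4ccc([N+](=O)[O-])cc4)nc23)cc(OC)c1OC`, which carries nitro, gives > 10000 nM, and this is a limit, not a number. Compound 3 `COc1cc(-c2nccn3cc(-c4ccc(O)cc4)nc23)cc(OC)c1OC`, which carries hydroxy, gives > 10000 nM, which is also a limit. Compound 2 therefore sits at the limit of > 10000 nM in this assay, at which 2 of the 3 values shown sit. Compound 4 `COc1cc(-c2nccn3cc(-c4ccc(C)cc4)nc23)cc(OC)c1OC` has methyl in place of nitro on an aromatic carbon.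

Among the compounds with values here, two measured steps bear on this change, both beyond the scatter: an at least 4.7-fold higher number from compound 1 to compound 2 (0.67 log units; beyond the scatter) and an at least 4.7-fold higher number from compound 1 to compound 3 (0.67 log units; beyond the scatter). The third, a step that the two limits leave unreadable from compound 2 to compound 3, adds nothing. With only these steps to go on, replacing nitro is expected to reverse a step of about the size of an at least 4.7-fold higher number from compound 1 to compound 2 (0.67 log units; beyond the scatter), bringing compound 4 near compound 1 in this assay. The estimated change is an at least 2.8-fold lower number from compound 2 to compound 4 (0.45 log units; beyond the scatter), towards a lower number. For compound 4 the expected value is 3500 nM, with an estimated range of 1200 nM to 10000 nM.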

Compound 4, half-maximal inhibitory concentration: 53 nM
Compound 4: the middle estimate sits 66-fold (1.82 log units) above what was measured, outside the stated range (below it).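

In this assay, within the data shown here, this position proves far more responsive than the earlier compounds showed, and compound 4 now leads the series: methyl in place of chloro gives a 39-fold lower number from compound 1 to compound 4 (1.60 log units; beyond the scatter), so chloro no longer marks the strongest result here. Methyl in place of nitro gives an at least 180-fold lower number from compound 2 to compound 4 (2.27 log units; beyond the scatter), and methyl in place of hydroxy gives an at least 180-fold lower number from compound 3 to compound 4 (2.27 log units; beyond the scatter). These last two steps give only a minimum size, and compound 2 is a limit, not a number: the limit of > 10000 nM in this assay, at which 2 of the 4 values shown sit.

The compounds shown leave open whether a longer chain such as ethyl, a methoxy group or an amine at this same place would match, exceed or lose the value of compound 4. They also leave open whether this order of groups holds in any other cell line.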